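A few compounds are considered here, and "the series" means these few. Any claim that something is new, unique, unknown or untested is made for them only; others in the source may bear on it.

In an assay on isolated protein for binding affinity to 5-hydroxytryptamine receptor 6 (Homo sapiens) (on this read-out higher numbers stand for weaker inhibition and lower numbers for stronger inhibition), compound 1 `CNCc1ccc(Cl)c(-c2ccccc2OC)c1` gives 1300 nM, and compound 2 `CCCCNCc1ccc(Cl)c(-c2ccccc2OC)c1` gives 240 nM, the lowest of the two numbers; the step of a 5.4-fold lower number from compound 1 to compound 2 (0.73 log units; beyond the scatter) is its nearest comparison. Compound 3 `CCCNCc1ccc(Cl)c(-c2ccccc2OC)c1` differs from compound 2 by hydrogen in place of methyl on a saturated chain carbon, three bonds along the chain from an amine nitrogen, a shorter trim of the same chain that was lengthened in that step. Going by the values given here, only the step from compound 1 to compound 2 bears on this, and it was modest for a longer addition, so a rise for compound 3 that stays within the scatter is expected, a 1.5-fold higher number from compound 2 to compound 3 (0.16 log units; within the scatter). Compound 3 is expected at 350 nM, within 170 nM to 750 nM.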

Compound 3, inhibition constant: 3500 nM
For compound 3 the middle estimate is 10-fold (1.00 log units) below the measured one; the measured number lies above the stated range.
By their numbers in this assay, from the lowest: compound 2; then compound 1; then compound 3.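

In this assay the cut from butyl to propyl proves large, a 15-fold higher number from compound 2 to compound 3 (1.16 log units; beyond the scatter), so this single methyl counts for much at this position. Chain length does not act in one direction: a 2.7-fold higher number from compound 1 to compound 3 (0.43 log units; beyond the scatter), whereas a 5.4-fold lower number from compound 1 to compound 2 (0.73 log units; beyond the scatter), so compound 3 goes against any steady trend with length. No measurement given here accounts for this reversal.

Where an ethyl chain would fall among these numbers remains open. So does whether a longer chain, such as pentyl, would stay nearer compound 2 or compound 3.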